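A few compounds are considered here, and "the series" means these few. Any claim that something is new, unique, unknown or untested is made for them only; others in the source may bear on it.

Of the compounds shown here, three built on one shared core have been measured in a functional assay on HT-29 cells (Homo sapiens) for cytotoxicity, read by MTT assay, with a stated time of 72 h; on this read-out lower numbers stand for stronger inhibition and higher numbers for weaker inhibition. Compound 2 `COc1cc2c(Oc3ccc(NC(=O)c4cn(-c5ccccc5)nn4)cc3F)ccnc2cc1OCCCN1CCN(C)CC1` gives 180 nM, compound 3 `COc1cc2c(Oc3ccc(NC(=O)c4cn(-c5ccccc5F)nn4)cc3F)ccnc2cc1OCCCN1CCN(C)CC1` gives 300 nM, and compound 1 `COc1cc2c(Oc3ccc(NC(=O)c4cn(-c5c(C)cccc5C)nn4)cc3F)ccnc2cc1OCCCN1CCCC1` gives 2240 nM. Compound 3 thus stands second highest of the three numbers, close to compound 2 and far from compound 1. The step of a 1.7-fold higher number from compound 2 to compound 3 (0.22 log units; within the scatter) shows that adding one fluorine changes little. Compound 4 `COc1cc2c(Oc3ccc(NC(=O)c4cn(-c5c(C)cccc5C)nn4)cc3F)ccnc2cc1OCCCN1CCN(C)CC1` makes a larger change at the same place: 2,6-dimethylphenyl in place of 2-fluorophenyl on an aromatic nitrogen. Going by the values given here, no measured step matches this exactly; compound 1 carries the same 2,6-dimethylphenyl with a different tail, and its number is far higher than those of compound 2 and compound 3. Compound 4 is therefore expected to give 1500 nM in this assay, within 400 nM to 5000 nM, an estimated step of a 5.0-fold higher number from compound 3 to compound 4 (0.70 log units; beyond the scatter).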

Compound 4, half-maximal inhibitory concentration: 2170 nM
Beside the measured number, compound 4's estimate is 1.4-fold (0.16 log units) below it; the measured number falls inside the stated range.
By their numbers in this assay, from the lowest: compounds 2 and 3 (each within the scatter of the next); then compounds 4 and 1 (each within the scatter of the next).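

In this assay, this position on the aromatic nitrogen proves far less tolerant than the fluorine step suggested: 2,6-dimethylphenyl gives a 7.2-fold higher number from compound 3 to compound 4 (0.86 log units; beyond the scatter) and a 12-fold higher number from compound 2 to compound 4 (1.08 log units; beyond the scatter). The tail, by contrast, makes no difference that can be read with this group in place, with 4-methylpiperazin-1-yl for pyrrolidin-1-yl giving a 1.0-fold lower number from compound 1 to compound 4 (0.01 log units; within the scatter). Nothing measured here explains the rise in the number. Going by these compounds, whether a single methyl, as in 2-methylphenyl, is enough to produce this rise remains open. So does whether the tail would matter with phenyl on that nitrogen.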